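The source may hold more compounds than are shown below. What is called first, only, known or untested is meant among the compounds shown, and "the series" means these compounds.

Measured in a functional assay for inhibition, with Rattus norvegicus as the target (on this read-out higher numbers stand for weaker inhibition and lower numbers for stronger inhibition), so far:
- compound 1 `CC(C)(C)c1ccc(C/N=C(\S)NC(c2ccccc2)c2ccc(NS(C)(=O)=O)cc2)cc1` gives 16700 nM
- compound 2 `CC(C)C(/N=C(\S)NCc1ccc(C(C)(C)C)cc1)c1ccc(NS(C)(=O)=O)cc1` gives 3240 nM

Compound 2 holds the lower of the two numbers, and its gap to compound 1 lies beyond the scatter. On this read-out, compound 2 is therefore the stronger inhibitor of the pair.

The next compound, compound 3 `CCCC(/N=C(\S)NCc1ccc(C(C)(C)C)cc1)c1ccc(NS(C)(=O)=O)cc1`, has not yet been measured. Its relation to compound 2 is propyl in place of isopropyl on a saturated chain carbon bound to an aromatic carbon and a double-bonded nitrogen, which puts propyl in place of isopropyl on a saturated chain carbon bound to an aromatic carbon and a double-bonded nitrogen. The two compounds have the same atoms, joined differently.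

For the measured compounds named here, the series so far has no measured step showing what a change of this kind does. The expectation therefore rests on compound 2 at 3240 nM as its only close reference. In this assay, as far as these compounds go, no shift beyond the scatter is expected, and the direction stays open. The expected move is a 1.1-fold lower number from compound 2 to compound 3 (0.03 log units; within the scatter), a small one. For compound 3 the estimate is 3000 nM, with an expected range from 1000 nM to 9000 nM.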

Compound 3, half-maximal inhibitory concentration: 1490 nM
For compound 3 the middle estimate is 2.0-fold (0.30 log units) above the measured one, within the range that was stated.
By their numbers in this assay, from the lowest: compound 3; then compound 2; then compound 1.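

In this assay this position gives its first readable step, a 2.2-fold lower number from compound 2 to compound 3 (0.34 log units; beyond the scatter), with propyl in place of isopropyl on a saturated chain carbon bound to an aromatic carbon and a double-bonded nitrogen. Isopropyl and propyl match in everything counted, with 3 heavy atoms, all carbon, no ring and no hydrogen-bond donors or acceptors, yet the step lies beyond the scatter, so at this position the read-out separates two groups that differ only in how the same carbons are joined. Nothing available bears on why propyl gives the lower number here.

As far as these compounds go, one step between two groups sets no trend, and it remains open whether a longer chain such as butyl or pentyl continues in the same direction as propyl or whether a shorter one such as ethyl reverses it. Also open, from the compounds shown here alone, is how this position responds to a small ring such as cyclopropyl, or to a chain that ends in a hydroxyl group or an amine.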